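Compound 4: exchanging the aromatic group on compound 3

This account rests on a few compounds, and the source may have more. Where it says the series, first, only, none or still open, it means among the compounds named here.

In a functional assay on HeLa cells (Homo sapiens) for inhibition, read by MTT assay, with a stated time of 72 h (on this read-out higher numbers stand for weaker inhibition and lower numbers for stronger inhibition), compound 3 `Nc1nc2cc(-c3nn(CCCCCCCCCC(=O)NO)c4ncnc(N)c34)ccc2o1` gives > 50000 nM, which is a limit and not a number. Compound 4 `Nc1ncnc2c1c(-c1cnc3[nH]ccc3c1)nn2CCCCCCCCCC(=O)NO` differs from compound 3 by one exchange on an aromatic carbon: a group of 9 heavy atoms (7 carbon, 2 nitrogen; one five-membered aromatic ring with 1 hetero atom, one six-membered aromatic ring with 1 hetero atom) in place of a group of 10 heavy atoms (7 carbon, 2 nitrogen, 1 oxygen; one five-membered aromatic ring with 2 hetero atoms, one six-membered aromatic ring of carbon only), on an aromatic carbon. Among the measured compounds shown here, the 2-amino-1,3-benzoxazol-5-yl group leaves, and the group that enters is the one already carried by compound 1 `CNC(=O)CCCCCCCn1nc(-c2cnc3[nH]ccc3c2)c2c(N)ncnc21` and compound 2 `Nc1ncnc2c1c(-c1cnc3[nH]ccc3c1)nn2CCCCCC(=O)NO`.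

In this assay, for the measured compounds named here, compound 1 gives 29100 nM, the only actual number so far. Compound 2 gives > 150000 nM, which is also a limit. Going by the values given here, the one measured step, an at least 5.1-fold higher number from compound 1 to compound 2 (0.71 log units; beyond the scatter), lies beyond the scatter, but it concerns the chain and its end group, not the aromatic group exchanged here. Among the compounds with values here, it therefore bears on compound 4 only indirectly, and no measured step covers the exchange itself.

Within the data shown here, compound 1 at 29100 nM is the only measured number with the entering group, so weak inhibition is expected to persist in compound 4. No large step is expected, and the expected step, an at least 1.2-fold lower number from compound 3 to compound 4 (0.09 log units; that floor lies within the scatter), can only be read against a limit. For compound 4 the estimated value is 40000 nM, with an expected range from 10000 nM to 150000 nM.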

Compound 4, half-maximal inhibitory concentration: 7560 nM
Compound 4: the middle estimate sits 5.3-fold (0.72 log units) above what was measured; measured number outside the range, below it.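

Until now only the chain and its end had changed; in this assay, the exchange on the aromatic carbon of the five-membered aromatic ring with 2 nitrogen also moves the read-out, with an at least 6.6-fold lower number from compound 3 to compound 4 (0.82 log units; beyond the scatter) when the 2-amino-1,3-benzoxazol-5-yl group leaves. The chain also proves decisive: 4-(hydroxycarbamoyl)butyl in place of hydroxycarbamoyl gives an at least 19-fold lower number from compound 2 to compound 4 (1.29 log units; beyond the scatter), and 2-(hydroxycarbamoyl)ethyl in place of methylcarbamoyl gives a 3.8-fold lower number from compound 1 to compound 4 (0.59 log units; beyond the scatter), the opposite direction to an at least 5.1-fold higher number from compound 1 to compound 2 (0.71 log units; beyond the scatter), so a hydroxycarbamoyl end does not by itself raise the number relative to compound 1. The steps from compound 2 and compound 3 start from limits and are floors only; for compound 2 that is: the limit of > 150000 nM in this assay, at which 1 of the 4 values shown sits.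

Still open, from the compounds shown here alone, is how a carboxylic acid or a primary amide in place of the hydroxycarbamoyl end would read on the chain of compound 4, and whether a longer chain would lower the number further. Also open, going by these compounds, is whether a plain phenyl group on the same aromatic carbon would read closer to compound 3 or to compound 4.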